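Cyano for methyl on the sulfonyl aryl: compound 4

The compounds below may be only part of what the source reports. "The series", "measured", "known", "first", "only" and "open" are said of these compounds alone.

Compound 3 `Cc1ccc(S(=O)(=O)N2N=C(c3ccc(N4CCN(C)CC4)cc3)CC2c2ccc(N(C)C)cc2)cc1` gives 10.7% in a functional assay on MDA-MB-231 cells (Homo sapiens) for inhibition, read by sulforhodamine B assay, tested at 10 uM (on this read-out higher numbers stand for more inhibition at the one concentration tested (going by the name of the read-out) and lower numbers for less inhibition), the highest number of the three measured, though its gap to compound 2 lies within the scatter. Compound 1 `Cc1ccc(C(=O)N2N=C(c3ccc(N4CCN(C)CC4)cc3)CC2c2ccc(N(C)C)cc2)cc1` gives -0.7% and compound 2 `CN1CCN(c2ccc(C3=NN(C(=O)c4ccc(F)cc4)C(c4ccc(N(C)C)cc4)C3)cc2)CC1` gives 3.5%; the step of a number 11.4 percentage points higher from compound 1 to compound 3 (beyond the scatter) is beyond the scatter, whereas a number 7.2 percentage points higher from compound 2 to compound 3 (within the scatter) and a number 4.2 percentage points higher from compound 1 to compound 2 (within the scatter) are not. Compound 4 `CN1CCN(c2ccc(C3=NN(S(=O)(=O)c4ccc(C#N)cc4)C(c4ccc(N(C)C)cc4)C3)cc2)CC1` differs from compound 3 in one place: cyano in place of methyl on an aromatic carbon. Among the compounds with values here, the only measured step that bears on exchanging a substituent on that aryl ring is a number 4.2 percentage points higher from compound 1 to compound 2 (within the scatter), which stayed within the scatter. No step beyond the scatter is therefore expected in this assay; the step of a number 1.3 percentage points higher from compound 3 to compound 4 (within the scatter) is the expectation. Compound 4 is estimated at 12%, with a range from 0% to 25%.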

Compound 4, a percentage reported as inhibition, at one concentration (the size of the read-out at that concentration, not a potency): 99.8%
The estimate for compound 4 lay 87.8 percentage points below the measured number; the whole stated range lies below it.
By their numbers in this assay, from the lowest: compounds 1, 2 and 3 (each within the scatter of the next, the first and the last beyond it); then compound 4.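

In this assay, the substituent on the sulfonyl aryl ring, para to a large group, proves decisive: cyano in place of methyl is a large step (a number 89.1 percentage points higher from compound 3 to compound 4 (beyond the scatter)), while fluoro in place of methyl on the carbonyl aryl ring stayed small (a number 4.2 percentage points higher from compound 1 to compound 2 (within the scatter)). The steps from the carbonyl compounds are equally large (a number 96.3 percentage points higher from compound 2 to compound 4 (beyond the scatter); a number 100.5 percentage points higher from compound 1 to compound 4 (beyond the scatter)), yet sulfonyl with 4-methylphenyl gave only a modest gain (a number 11.4 percentage points higher from compound 1 to compound 3 (beyond the scatter)). No available evidence explains this jump.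

Open, on these data alone, is whether 4-cyanophenyl on a carbonyl keeps this level, and whether a nitro group, a carboxylic acid or an amide at the same place matches cyano.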